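Bromo and methoxy replacing fluoro on the hydroxyphenyl group

This account rests on a few compounds, and the source may have more. Where it says the series, first, only, none or still open, it means among the compounds named here.

Going by the values given here, compound 2 (`COc1ccc(/C=C/C(=O)C(=Cc2ccc(O)c(F)c2)C(=O)/C=C/c2ccc(OC)cc2OC)c(OC)c1`) gives 2070 nM in a functional assay on A549 cells (Homo sapiens) for antiproliferative activity, read by sulforhodamine B assay, with a stated time of 48 h (on this read-out lower numbers stand for stronger inhibition and higher numbers for weaker inhibition), and holds the higher of the two numbers so far, while compound 1 (`COc1ccc(/C=C/C(=O)C(=Cc2ccc(O)c(OC)c2)C(=O)/C=C/c2ccc(OC)cc2OC)c(OC)c1`) gives 590 nM in the same test. Compound 3 (`COc1ccc(/C=C/C(=O)C(=Cc2cc(Br)c(O)c(OC)c2)C(=O)/C=C/c2ccc(OC)cc2OC)c(OC)c1`) carries 3-bromo-4-hydroxy-5-methoxyphenyl in place of 3-fluoro-4-hydroxyphenyl (3-bromo-4-hydroxy-5-methoxyphenyl in place of 3-fluoro-4-hydroxyphenyl on a double-bonded chain carbon bound to a double-bonded chain carbon) on a double-bonded chain carbon bound to a double-bonded chain carbon. Among the compounds with values here, one measured step bears on this: a 3.5-fold higher number from compound 1 to compound 2 (0.55 log units; beyond the scatter) with fluoro in place of methoxy on an aromatic carbon. Within the data shown here, compound 3 has a methoxy group, as compound 1 does, but no measured compound shows what bromo does here. A modest move to a lower number is therefore expected, an estimated 2.3-fold lower number from compound 2 to compound 3 (0.36 log units; beyond the scatter) in this assay with wide uncertainty. Compound 3 is expected near 900 nM in this assay with an estimated range from 350 nM to 2300 nM on repeated measurement.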

Compound 3, half-maximal inhibitory concentration: 1090 nM
The estimate for compound 3 lay 1.2-fold (0.08 log units) below the measured number, within the range that was stated.
By their numbers in this assay, from the lowest: compounds 1, 3 and 2 (each within the scatter of the next, the first and the last beyond it).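

In this assay, bromo in place of hydrogen on an aromatic carbon gives a 1.8-fold higher number from compound 1 to compound 3 (0.27 log units; within the scatter), so the one bromo group shown cannot be told apart from hydrogen at this level of scatter. The larger exchange of 3-fluoro-4-hydroxyphenyl for 3-bromo-4-hydroxy-5-methoxyphenyl gives a 1.9-fold lower number from compound 2 to compound 3 (0.28 log units; within the scatter), also within the scatter, so these two groups on a double-bonded chain carbon bound to a double-bonded chain carbon cannot be ranked, whereas fluoro in place of methoxy gave a 3.5-fold higher number from compound 1 to compound 2 (0.55 log units; beyond the scatter), beyond it. No measurement at hand accounts for these numbers.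

Still open, from the compounds shown here alone, is how an amine or a carboxylic acid in the place of bromo would read in this assay. All compounds shown keep the hydroxy group, so the effect of replacing it with an amine also remains open.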